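Notes on a three-compound series and a fourth to measure

The compounds below may be only part of what the source reports. "The series", "measured", "known", "first", "only" and "open" are said of these compounds alone.

Measured so far:
- compound 1 `Cc1ccc(Nc2nc(Cl)nc3c2ncn3Cc2ccc(C(=O)Nc3ccccc3N)cc2)cc1` gives 76.3%
- compound 2 `Nc1ccccc1NC(=O)c1ccc(Cn2cnc3c(NCc4ccccc4)nc(Cl)nc32)cc1` gives 68.3%
- compound 3 `Nc1ccccc1NC(=O)c1ccc(Cn2cnc3c(Nc4cccc(Cl)c4)nc(Cl)nc32)cc1` gives 56.2%

All three numbers come from a functional assay on HCT-116 cells (Homo sapiens) for antiproliferative activity, read by CCK-8 assay, with a stated time of 72 h, tested at 2 uM; on this read-out higher numbers stand for a stronger effect at the one concentration tested and lower numbers for a weaker effect. Compound 3 stands lowest of the three: the step of a number 20.1 percentage points lower from compound 1 to compound 3 (beyond the scatter) and the step of a number 12.1 percentage points lower from compound 2 to compound 3 (beyond the scatter) both lie beyond the scatter, while the step of a number 8 percentage points lower from compound 1 to compound 2 (within the scatter) does not. Each measured step exchanges only the group carried on the nitrogen attached to the shared core, and that nitrogen keeps its hydrogen in every case.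

Compound 4 `CN1CCN(c2nc(Cl)nc3c2ncn3Cc2ccc(C(=O)Nc3ccccc3N)cc2)CC1` is different in kind: 4-methylpiperazin-1-yl in place of (3-chlorophenyl)amino on an aromatic carbon. Within the data shown here, no measured step removes the (3-chlorophenyl)amino nitrogen itself or puts a non-aromatic ring in its place, so none of the three steps bears directly on this change. The measured steps show that swapping the aryl or benzyl group on that nitrogen moves the read-out by modest amounts, but they give no guide to what happens when the whole group is replaced. The expectation for compound 4 is therefore uncertain and leans toward a weaker effect, with the step of a number 16.2 percentage points lower from compound 3 to compound 4 (beyond the scatter) estimated downward. Compound 4 is estimated at 40%, within a wide range from 10% to 70%.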

Compound 4, a percentage reported as inhibition, at one concentration (the size of the read-out at that concentration, not a potency): 71.6%
For compound 4 the middle estimate is 31.6 percentage points below the measured one; measured number outside the range, above it.
By their numbers in this assay, from the lowest: compound 3; then compounds 2, 4 and 1 (each within the scatter of the next).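

In this assay, the change at this aromatic carbon next to the ring nitrogen replaces the whole substituent rather than only the group on its nitrogen, and the read-out survives it, as the step to the 4-methylpiperazin-1-yl group shows (a number 15.4 percentage points higher from compound 3 to compound 4 (beyond the scatter)). The same group stands level with the benzylamino and (4-methylphenyl)amino groups (a number 3.3 percentage points higher from compound 2 to compound 4 (within the scatter); a number 4.7 percentage points lower from compound 1 to compound 4 (within the scatter)), so among these four compounds neither an aromatic ring at this position nor a hydrogen-bond donor is needed for an effect of this size at the one concentration tested, and compound 3 is the one that sits apart. Nothing available on these compounds accounts for this result.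

Still open, on these data alone, is which part of the entering group carries the result: a morpholin-4-yl ring, a piperazine without the methyl group, or an open-chain dimethylamino group would separate the ring from its second nitrogen and its methyl. Also open, as far as these compounds go, is whether the level read-outs at this single concentration would stay level at other concentrations, and whether the chloro group meta to this position can be exchanged alongside the 4-methylpiperazin-1-yl group.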